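Moving one methyl group: from compound 2 to compound 3

This account rests on a few compounds, and the source may have more. Where it says the series, first, only, none or still open, it means among the compounds named here.

Going by the values given here, in a functional assay on HepG2 cells (Homo sapiens) for inhibition, read by MTT assay, with a stated time of 24 h (on this read-out higher numbers stand for weaker inhibition and lower numbers for stronger inhibition), compound 2 (`Cc1ccccc1-n1cc(CN2C(=O)C[C@@H]3CC[C@@]2(C)C3(C)C)nn1`) gives 150 nM as the higher of the two numbers so far, which makes it the weaker inhibitor of the pair. Compound 1 (`CC1(C)[C@H]2CC[C@]1(C)N(Cc1cn(-c3cccc(O)c3)nn1)C(=O)C2`) gives 70 nM on the same read-out. Compound 3 (`Cc1cccc(-n2cc(CN3C(=O)C[C@@H]4CC[C@@]3(C)C4(C)C)nn2)c1`) keeps the core of compound 2 and changes one group, with 3-methylphenyl in place of 2-methylphenyl on an aromatic nitrogen. Among the compounds with values here, only one measured step bears on this, and it came with 2-methylphenyl in place of 3-hydroxyphenyl (a 2.1-fold higher number from compound 1 to compound 2 (0.33 log units; beyond the scatter)). That step is modest. Compound 3 shares its methyl group with compound 2 and its ring numbering with compound 1, so only a slight move seems likely. In this assay the expected change stays within the scatter, leaning towards a lower number (a 1.4-fold lower number from compound 2 to compound 3 (0.13 log units; within the scatter)). Compound 3 is estimated at 110 nM with 50 nM and 240 nM as the expected ends of its range.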

Compound 3, half-maximal inhibitory concentration: 300 nM
Compound 3: the middle estimate sits 2.7-fold (0.44 log units) below what was measured; measured number outside the range, above it.
By their numbers in this assay, from the lowest: compound 1; then compounds 2 and 3 (each within the scatter of the next).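

Moving the methyl group on the aromatic ring, with 3-methylphenyl in place of 2-methylphenyl, gives a difference in this assay that stays within the scatter (a 2.0-fold higher number from compound 2 to compound 3 (0.30 log units; within the scatter)), so these data cannot separate the two placements. The step from hydroxy to methyl on an aromatic carbon is new. It changes the group without moving it, and it lies beyond the scatter (a 4.3-fold higher number from compound 1 to compound 3 (0.63 log units; beyond the scatter)). Compound 1, with its 3-hydroxyphenyl group, therefore keeps the lowest number of the three, and the earlier step had changed both group and placement at once. Nothing measured here explains this gap between hydroxy and methyl. Going by these compounds, whether a methoxy group, an amine or a carboxylic acid in place of that hydroxy would keep the lower number remains open.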